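A Longer Ether Chain on a Shared Core

A few compounds are considered here, and "the series" means these few. Any claim that something is new, unique, unknown or untested is made for them only; others in the source may bear on it.

Three compounds share one core and differ only in the group on one aromatic carbon: compound 1 `Nc1nc(OCC(F)(F)F)c2ncn(/C=C3/CC3(CO)CO)c2n1`, compound 2 `CN(C)c1nc(N)nc2c1ncn2/C=C1/CC1(CO)CO` and compound 3 `CCCNc1nc(N)nc2c1ncn2/C=C1/CC1(CO)CO`. All three were tested in an ADME assay on Akata cells (Homo sapiens) for cytotoxicity, with a stated time of 7 days; on this read-out lower numbers stand for higher toxicity in this test and higher numbers for lower toxicity in this test. Compound 1 gives > 20000 nM, which is a limit of the assay rather than a number. Compound 2 gives > 24000 nM, again a limit. Compound 3 gives > 24000 nM, also a limit. Compound 3 therefore stands where the other two stand, and the only landmarks in this assay are the limit of > 20000 nM in this assay, at which 1 of the 3 values shown sits, and (the limit of > 24000 nM in this assay, at which 2 of the 3 values shown sit).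

Compound 4 `CCCCCCOc1nc(N)nc2c1ncn2/C=C1/CC1(CO)CO` is the next step: hexyloxy in place of propylamino on an aromatic carbon. The measured steps that bear on this change are a step that the two limits leave unreadable from compound 1 to compound 2, a step that the two limits leave unreadable from compound 1 to compound 3 and a step that the two limits leave unreadable from compound 2 to compound 3; none of them has a readable size, since each runs between two limits. Nothing in the numbers therefore points to a step in this assay beyond the scatter in either direction, and another limit is the most likely outcome. Compound 4 is expected to give about 30000 nM, within 10000 nM to 100000 nM. This estimate means a step that the limit leaves unreadable from compound 3 to compound 4.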

Compound 4, half-maximal cytotoxic concentration: > 20000 nM
Compound 4 was reported as a limit; the forecaster's own chance of this, stated with the estimate: 80%; the middle value is on the limit's open side.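

In this assay compounds 1, 2, 3 and 4 all stand as limits, and the steps from compounds 1, 2 and 3 to compound 4 cannot be read. From the compounds shown here alone, what remains open is the concentration, if any, at which these four compounds harm the cells, and whether hexyloxy on the shared core differs at all from propylamino, dimethylamino or 2,2,2-trifluoroethoxy.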